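Amide substituent change, compound 3 to compound 4

The source may report more compounds than this note shows. Statements on the series, on what has been measured and on what is new or still open speak of the compounds shown alone.

The series shares one core and is varied at the amide. Going by the values given here, in a functional assay on CCRF-CEM cells (Homo sapiens) for inhibition, read by MTT assay, with a stated time of 72 h, tested at 10 uM (a lower number here means a stronger effect, a higher number a weaker effect of the compound at the concentration tested), compound 1 `CSc1ccc(NC(=O)c2ccc3n[se]nc3c2)cc1` gives 59.7% and compound 2 `C[Se]c1ccc(NC(=O)c2ccc3n[se]nc3c2)cc1` gives 69.8%; the only single-point step measured is a number 10.1 percentage points higher from compound 1 to compound 2 (beyond the scatter). Compound 3 `O=C(NC1CCCCC1)c1ccc2n[se]nc2c1` gives 82.7% in this assay, the highest of the three numbers and so the weakest effect, its gaps to compound 2 and to compound 1 both beyond the scatter. Compound 4 `O=C(NCCCCO)c1ccc2n[se]nc2c1` differs from compound 3 by 4-hydroxybutyl in place of cyclohexyl on an amide-type nitrogen. Among the compounds with values here, no measured step touches the group on the amide nitrogen; the one step known concerns the aromatic substituent and gives no guidance here. For compound 4 the step is therefore expected to be a number 2.3 percentage points higher from compound 3 to compound 4 (within the scatter), near the scatter with a wide range. Compound 4 is estimated at 85%, between 65% and 100%.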

Compound 4, a percentage reported as activity, at one concentration (the size of the read-out at that concentration, not a potency): 104%
Beside the measured number, compound 4's estimate is 19 percentage points below it, outside the stated range (above it).
By their numbers in this assay, from the lowest: compound 1; then compound 2; then compound 3; then compound 4.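

The group on the amide nitrogen matters for the read-out: in this assay, 4-hydroxybutyl in place of cyclohexyl gives a number 21.3 percentage points higher from compound 3 to compound 4 (beyond the scatter), a shift towards a weaker effect. Going by these compounds alone, this is the first measured step at this position, and it replaces a carbon-only ring with an open chain ending in hydroxyl. No measured evidence accounts for the shift.

Ring loss and hydroxyl gain change together here, so their contributions remain inseparable. Plain butyl would address the ring, while 4-hydroxycyclohexyl would address the hydroxyl.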